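This account rests on a few compounds, and the source may have more. Where it says the series, first, only, none or still open, it means among the compounds named here.

Measured so far:
compound 1 `COc1ccc(/C(F)=C\c2cc(OC)c(OC)c(OC)c2)cc1N` — 2100 nM
compound 2 `COc1cc(/C(F)=C/c2cc(O)c3ccoc3c2)cc(OC)c1OC` — > 1000 nM
compound 3 `COc1ccc(/C(F)=C/c2cc(OC)c(OC)c(OC)c2)cc1N` — 111000 nM

In a functional assay on cells (Endothelial cell, Bos taurus) for antiproliferative activity (on this read-out higher numbers stand for weaker inhibition and lower numbers for stronger inhibition), compound 3 gives 111000 nM, the highest of the two numbers given; its nearest neighbour is compound 1, and the step of a 53-fold higher number from compound 1 to compound 3 (1.72 log units; beyond the scatter) is large and beyond the scatter, the two compounds differing only in configuration as drawn (the fact that compounds 1 and 3 differ only in the configuration as drawn). For compound 2 the value > 1000 nM is a limit of this assay and not a number (the limit of > 1000 nM in this assay, at which 1 of the 3 values shown sits).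

Compound 4 `COc1ccc(/C(F)=C/c2cc(OC)c(OC)c(OC)c2)cc1F` is the next compound to be measured in this assay. It differs from compound 3 by fluoro in place of amino on an aromatic carbon. For the measured compounds named here, no measured step concerns this kind of change: the only step in hand, from compound 1 to compound 3, is a change of configuration alone and says nothing about the amino or fluoro group. The expectation for compound 4 therefore rests on compound 3 alone, and the step of a 1.1-fold lower number from compound 3 to compound 4 (0.05 log units; within the scatter) is expected to be small, with no direction that can be supported. Compound 4 is estimated at 100000 nM, within 20000 nM to 500000 nM.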

Compound 4, half-maximal inhibitory concentration: 610000 nM
Compound 4: the middle estimate sits 6.1-fold (0.79 log units) below what was measured; measured number above the stated range.
By their numbers in this assay, from the lowest: compound 1; then compound 3; then compound 4.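

In this assay the first change read at this position is a 5.5-fold higher number from compound 3 to compound 4 (0.74 log units; beyond the scatter), so the position is not indifferent to the group it carries when fluoro stands in place of amino on the aromatic carbon ortho to a methoxy group. Both compounds have the same configuration as drawn, so this step is read apart from the earlier step, which was a change of configuration alone. Nothing at hand gives a cause for this step, and the data do not separate the loss of amino from the entry of fluoro.

Going by these compounds, whether the same change has a similar size in the configuration of compound 1 stays open. Also open, on these data alone, is how a dimethylamino or an acetamido group at this position would read in this assay, and whether the hydrogen-bond donor that leaves with amino matters to the number.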